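The compounds below may be only part of what the source reports. "The series", "measured", "known", "first", "only" and "open" are said of these compounds alone.

Within the data shown here, compound 1 `CC1CCN(c2nc(C(F)(F)F)ccc2CNC(=O)C(c2ccc(NS(C)(=O)=O)c(F)c2)C2CCCC2)CC1` is one of three compounds measured in an assay on CHO cells for antagonist activity at transient receptor potential cation channel subfamily V member 1 (Homo sapiens), read by FLIPR (on this read-out higher numbers stand for weaker inhibition and lower numbers for stronger inhibition), and in that assay compound 1 gives 88.7 nM, the highest of the three numbers. Compound 3 `CC1CCN(c2nc(C(F)(F)F)ccc2CNC(=O)C(Cc2ccccc2)c2ccc(NS(C)(=O)=O)c(F)c2)CC1` is nearest to it: in this assay compound 3 gives 65.9 nM, and the step of a 1.3-fold lower number from compound 1 to compound 3 (0.13 log units; within the scatter) stays within the scatter. Among the measured compounds shown here, compound 2 `Cc1ccc(C(C(=O)NCc2ccc(C(F)(F)F)nc2SC2CCCCC2)c2ccc(NS(C)(=O)=O)c(F)c2)cc1` is furthest away; in this assay compound 2 gives 7.5 nM, but it differs from compound 1 in more than one place, so no single step links the two.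

Compound 4 `CC1CCN(c2nc(C(F)(F)F)ccc2CNC(=O)C(Cc2ccc(F)cc2)c2ccc(NS(C)(=O)=O)c(F)c2)CC1` is not yet measured. It differs from compound 1 by 4-fluorobenzyl in place of cyclopentyl on a saturated chain carbon bound to an aromatic carbon and a carbonyl carbon. For the measured compounds named here, the one measured step that bears on this change is a 1.3-fold lower number from compound 1 to compound 3 (0.13 log units; within the scatter), since benzyl and 4-fluorobenzyl are closely related groups at the same place, and that step was within the scatter. Compound 4 is therefore expected to show a step of about a 1.5-fold lower number from compound 1 to compound 4 (0.17 log units; within the scatter) in this assay, with no clear change beyond the scatter. The estimated value for compound 4 is 60 nM, within a range from 25 nM to 150 nM.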

Compound 4, inhibition constant: 49.3 nM
The estimate for compound 4 lay 1.2-fold (0.09 log units) above the measured number; low and high end bracket the measured number.
By their numbers in this assay, from the lowest: compound 2; then compounds 4, 3 and 1 (each within the scatter of the next).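

In this assay, 4-fluorobenzyl in place of cyclopentyl on this saturated chain carbon gives a 1.8-fold lower number from compound 1 to compound 4 (0.26 log units; within the scatter), so a second aromatic group carrying a fluoro substituent also stays within the scatter of the cyclopentyl compound. Fluoro in place of hydrogen on an aromatic carbon of the benzyl group gives a 1.3-fold lower number from compound 3 to compound 4 (0.13 log units; within the scatter), the only reading here of a substituent on that ring, and it shows no change beyond the scatter.

No measurement at hand bears on the reason for these readings. Going by these compounds, whether a methoxy group or a carboxylic acid on that ring, or a longer chain at this carbon, would move the number beyond the scatter stays open.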